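Trading Trifluoromethyl for Trifluoromethoxy: Cytotoxicity Outlook

The compounds below may be only part of what the source reports. "The series", "measured", "known", "first", "only" and "open" are said of these compounds alone.

Compound 1, `COc1ccc(-c2ccc(CO[C@@H]3COc4nc([N+](=O)[O-])cn4C3)s2)cn1`, in an ADME assay on Vero cells (Chlorocebus sabaeus) for cytotoxicity, with a stated time of 72 h (a higher number here means a weaker inhibitor, a lower number a stronger inhibitor), gives > 128000 nM, a limit of the assay and not a number.
Compound 2, `COc1ccc(-c2nc(CO[C@@H]3COc4nc([N+](=O)[O-])cn4C3)cs2)cc1F`, in this assay gives > 128000 nM, again a limit rather than a number.
Compound 3, `Cn1c(CO[C@@H]2COc3nc([N+](=O)[O-])cn3C2)cnc1-c1ccc(C(F)(F)F)cc1`, in this assay gives > 128000 nM, also a limit.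

Of the compounds shown here, three with a shared core have been tested for toxicity toward these cells. None of them yields an actual number: each result is only a limit. Compound 3 therefore stands in the same place as the other two, at the limit (the limit of > 128000 nM in this assay, at which 3 of the 3 values shown sit), so nothing separates these compounds on the numbers shown, and no ranking of strength among them can be made.

Compound 4, `Cn1c(CO[C@@H]2COc3nc([N+](=O)[O-])cn3C2)cnc1-c1ccc(OC(F)(F)F)cc1`, has not yet been measured in this assay. It differs from compound 3 in one place: trifluoromethoxy in place of trifluoromethyl on an aromatic carbon. Going by the values given here, with every measured compound sitting at the limit, there is no step between measured compounds to draw on. The expectation is that this change produces no step beyond the scatter, namely a step that the limit leaves unreadable from compound 3 to compound 4, and that compound 4 will most likely also be reported as a limit. The estimate for compound 4 is 200000 nM, with a range from 100000 nM to 600000 nM.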

Compound 4, half-maximal inhibitory concentration: > 128000 nM
Compound 4: no number, only a limit (the forecaster's own chance of this, stated with the estimate: 90%); the middle value is on the limit's open side.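

Compound 3 and compound 4 both end at a limit rather than a number, so no step between them can be read in this assay: the limit of > 128000 nM in this assay, at which 4 of the 4 values shown sit.

The compounds shown leave open how strongly any of them acts on these cells, and whether trifluoromethoxy in place of trifluoromethyl changes that at all.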